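Same Small Change Tried on Two Different Cores

The source may hold more compounds than are shown below. What is called first, only, known or untested is meant among the compounds shown, and "the series" means these compounds.

Compound 1 `Cc1ccccc1C(=O)Nc1sc2c(c1C(N)=O)CCN(C(=S)Nc1ccccc1Cl)C2` and compound 2 `COc1ccccc1C(=O)Nc1sc2c(c1C(N)=O)CCN(C(=S)Nc1ccccc1Cl)C2` differ in one place: methoxy in place of methyl on an aromatic carbon. In a functional assay on MKN-74 cells (Homo sapiens) for antiproliferative activity, with a stated time of 24 h (a higher number here means a weaker inhibitor, a lower number a stronger inhibitor), compound 1 gives 11000 nM, and compound 2 gives 20500 nM, a step of a 1.9-fold higher number from compound 1 to compound 2 (0.27 log units; within the scatter). Compound 3 `Cc1ccccc1NC(=S)N1CCc2c(sc(NC(=O)c3ccccc3C(F)(F)F)c2C(N)=O)C1` and compound 4 `COc1ccccc1NC(=S)N1CCc2c(sc(NC(=O)c3ccccc3C(F)(F)F)c2C(N)=O)C1` share a different core; how that core differs from the core of compound 1 is not broken down here. In this assay compound 3 gives 47400 nM, the highest number among the three measured compounds. Compound 4 carries the same change that turns compound 1 into compound 2: methoxy in place of methyl on an aromatic carbon, at a place described in exactly the same words. Because that change produced a 1.9-fold higher number from compound 1 to compound 2 (0.27 log units; within the scatter) on the first core, a similar step is expected here, a 1.5-fold higher number from compound 3 to compound 4 (0.17 log units; within the scatter). The estimate for compound 4 is therefore 70000 nM, expected to fall between 30000 nM and 160000 nM.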

Compound 4, half-maximal inhibitory concentration: 34500 nM
For compound 4 the middle estimate is 2.0-fold (0.31 log units) above the measured one; measured number inside the range.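

In this assay methoxy in place of methyl gives a 1.4-fold lower number from compound 3 to compound 4 (0.14 log units; within the scatter), so compound 3 and compound 4 cannot be told apart. The steps on the two cores cannot be told apart either: the same change on two cores in this assay, a 1.9-fold higher number (0.27 log units; within the scatter) from compound 1 to compound 2 and a 1.4-fold lower number (0.14 log units; within the scatter) from compound 3 to compound 4, 2.6-fold (0.41 log units) apart, within the scatter of two such steps. Within the data shown here, this shows that the swap makes no clear difference on either core, but such small steps from only two pairs cannot show that a real effect carries from one core to the other.

The compounds shown leave open whether a different group in the same place, such as an amine, a carboxylic acid or a longer chain, would give a step beyond the scatter. They also leave open how the swap would behave on further cores.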